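The compounds below may be only part of what the source reports. "The series", "measured", "known", "first", "only" and "open" are said of these compounds alone.

Three amides on the shared core have been measured so far in a functional assay on ID8 cells (Mus musculus) for antiproliferative activity (a higher number here means a weaker inhibitor, a lower number a stronger inhibitor), with compound 1 `O=C(Nc1ccc(O)c2c(=O)cc(-c3ccccc3Cl)oc12)c1ccc(Cl)c(Cl)c1` at 13000 nM and compound 2 `Cc1ccc(C(=O)Nc2ccc(O)c3c(=O)cc(-c4ccccc4Cl)oc23)cc1` at 16000 nM while compound 3 `COc1ccc(C(=O)Nc2ccc(O)c3c(=O)cc(-c4ccccc4Cl)oc23)cc1` gives 5000 nM as the lowest of the three numbers. Compound 4 `CS(=O)(=O)Nc1ccc(O)c2c(=O)cc(-c3ccccc3Cl)oc12` carries methylsulfonyl in place of (4-methoxyphenyl)carbonyl on a nitrogen on an aromatic ring (counted difference: methylsulfonyl in place of (4-methoxyphenyl)carbonyl on a nitrogen on an aromatic ring). The measured steps only vary the group on the carbonyl. They are a 2.6-fold lower number from compound 1 to compound 3 (0.41 log units; beyond the scatter) and a 3.2-fold lower number from compound 2 to compound 3 (0.51 log units; beyond the scatter) and also a 1.2-fold higher number from compound 1 to compound 2 (0.09 log units; within the scatter) so they guide this replacement only loosely. A modest rise in this assay is expected since compound 3 at 5000 nM sits lowest. The estimate is a 2.4-fold higher number from compound 3 to compound 4 (0.38 log units; beyond the scatter) as the expected step. Compound 4 is expected at 12000 nM within a range of 3500 nM to 40000 nM on this estimate.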

Compound 4, half-maximal inhibitory concentration: 16000 nM
Compound 4: middle estimate off by 1.3-fold (0.12 log units), on the low side; low and high end bracket the measured number.
By their numbers in this assay, from the lowest: compound 3; then compounds 1, 2 and 4 (each within the scatter of the next).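

In this assay, methylsulfonyl on the nitrogen gives a 3.2-fold higher number from compound 3 to compound 4 (0.51 log units; beyond the scatter), yet there is no change at the digits printed from compound 2 to compound 4 (within the scatter) and a 1.2-fold higher number from compound 1 to compound 4 (0.09 log units; within the scatter). The aromatic ring and carbonyl of the leaving groups are therefore not required to match compounds 1 and 2 here, and only the (4-methoxyphenyl)carbonyl group of compound 3 stands apart from methylsulfonyl. No supporting data bear on the reason for this pattern.

On these data alone, it remains open whether a 4-methoxyphenylsulfonyl group on this nitrogen would track compound 3 or compound 4. A free amine at this place is equally unresolved.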